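The compounds below may be only part of what the source reports. "The series", "measured", "known", "first", "only" and "open" are said of these compounds alone.

Compound 1 `COc1cc(/C=C/C(=O)c2cccc(-n3cc(-c4ccccc4)[nH]c3=O)c2)cc(OC)c1OC` — in a functional assay on RXF 393 cells (Homo sapiens) for inhibition (on this read-out higher numbers stand for weaker inhibition of growth and lower numbers for stronger inhibition of growth), compound 1 gives 1710 nM
Compound 2 `COc1cc(/C=C/C(=O)c2cccc(-n3cc(-c4ccccc4)[nH]c3=O)c2)ccc1O` — in this assay compound 2 gives 2270 nM
Compound 3 `O=C(/C=C/c1cccc(O)c1)c1cccc(-n2cc(-c3ccc(Cl)cc3)[nH]c2=O)c1` — in this assay compound 3 gives 1510 nM

Compound 2 carries the highest of the three numbers, but its gaps to compound 1 and to compound 3 both lie within the scatter, so no order among the three can be drawn from these values. Compound 4 `COc1ccc(-c2cn(-c3cccc(C(=O)/C=C/c4ccc(O)c(OC)c4)c3)c(=O)[nH]2)cc1` has not yet been measured in this assay. It differs from compound 2 by methoxy in place of hydrogen on an aromatic carbon. Going by the values given here, no pair of measured compounds isolates a change of this kind, so nothing measured here tells the size of such a step. The expectation is that the step of a 1.1-fold lower number from compound 2 to compound 4 (0.05 log units; within the scatter) stays within the scatter, with no clear direction. Compound 4 is therefore estimated at 2000 nM, expected to fall between 900 nM and 4500 nM.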

Compound 4, concentration for 50% growth inhibition: 5850 nM
The estimate for compound 4 lay 2.9-fold (0.47 log units) below the measured number; the whole stated range lies below it.
By their numbers in this assay, from the lowest: compounds 3, 1 and 2 (each within the scatter of the next); then compound 4.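

In this assay, going by these compounds alone, the change from phenyl to 4-methoxyphenyl gives a 2.6-fold higher number from compound 2 to compound 4 (0.41 log units; beyond the scatter) and is the first single change that can be read, a modest loss of growth inhibition at this position. The compounds shown give no reason for this step.

Open, from the compounds shown here alone, is whether the loss belongs to methoxy alone or to any group at this place, which an amine or a carboxylic acid there would help to settle. Compound 3 differs from the others in more than one place, so it cannot answer this.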